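Swapping Pyridine for Piperidine in a Bombesin Receptor Agonist

The compounds below may be only part of what the source reports. "The series", "measured", "known", "first", "only" and "open" are said of these compounds alone.

Measured compounds:
compound 1, `CCC(C)(C)Cc1c[nH]c(CCc2ccc(-c3ccncc3)cc2)n1`, 15 nM
compound 2, `CCC(C)(C)Cc1c[nH]c(CCc2ccc(-n3ccnn3)cc2)n1`, 57 nM
compound 3, `CCC(C)(C)Cc1c[nH]c(CCc2ccc(-c3cccnc3)cc2)n1`, 4.3 nM

All three share one core and differ only in the ring attached to the outer benzene. In a functional assay on HEK293 cells for agonist activity at Bombesin receptor subtype-3 (Mus musculus), read by luminescence and calcium flux, with a stated time of 10 min (on this read-out higher numbers stand for an effect only at larger amounts of compound and lower numbers for an effect already at smaller amounts), compound 3 gives the lowest number of the three: a 3.5-fold lower number from compound 1 to compound 3 (0.54 log units; beyond the scatter) and a 13-fold lower number from compound 2 to compound 3 (1.12 log units; beyond the scatter), both beyond the scatter, so compound 3 is the most potent of the measured set.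

Compound 4, `CCC(C)(C)Cc1c[nH]c(CCc2ccc(N3CCCCC3)cc2)n1`, has not yet been measured. It differs from compound 3 in one place: piperidin-1-yl in place of pyridin-3-yl on an aromatic carbon. The ring that enters has the same number of heavy atoms and the same single hetero atom, but it is no longer aromatic.

The two steps that bear on this change are those that lead to compound 3. Moving the ring nitrogen by one position gave a 3.5-fold lower number from compound 1 to compound 3 (0.54 log units; beyond the scatter), a modest step, and exchanging a triazole for the pyridine gave a 13-fold lower number from compound 2 to compound 3 (1.12 log units; beyond the scatter), a large one. Each swap of the outer ring so far has moved the number beyond the scatter, and compound 3 already holds the lowest value, so a step upward is more likely than a further drop. For compound 4 the expected step is a 9.3-fold higher number from compound 3 to compound 4 (0.97 log units; beyond the scatter) in this assay. The estimate for compound 4 is therefore 40 nM, with a range from 10 nM to 160 nM.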

Compound 4, half-maximal effective concentration: 28 nM
Beside the measured number, compound 4's estimate is 1.4-fold (0.15 log units) above it, within the range that was stated.
By their numbers in this assay, from the lowest: compound 3; then compounds 1 and 4 (each within the scatter of the next); then compound 2.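

In this assay, compound 4 shows that this position still accepts a non-aromatic ring, although exchanging pyridin-3-yl for piperidin-1-yl, with the same count of heavy atoms and the same single hetero atom, gives a 6.5-fold higher number from compound 3 to compound 4 (0.81 log units; beyond the scatter) and so gives up the lowest number in the set. Aromatic rings do not all rank ahead of the non-aromatic one, however: the exchange of 1H-1,2,3-triazol-1-yl for piperidin-1-yl gives a 2.0-fold lower number from compound 2 to compound 4 (0.31 log units; beyond the scatter), and compound 2 therefore goes against any rule that an aromatic ring is always better here, while the exchange of pyridin-4-yl for piperidin-1-yl gives a 1.9-fold higher number from compound 1 to compound 4 (0.27 log units; within the scatter) and so separates those two compounds by no more than the usual scatter. No measurement among these compounds accounts for any of these differences, so the reason for them remains unknown.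

The compounds shown leave open whether the ring nitrogen matters at all, which a cyclohexyl ring, carrying only carbon, could test against compound 4. They also leave open how a morpholin-4-yl ring, with an oxygen added to the non-aromatic ring, would compare with compound 4 in this assay.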